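Methoxy in place of chloro in compound 4

The compounds below may be only part of what the source reports. "The series", "measured", "known", "first", "only" and "open" are said of these compounds alone.

In an ADME assay on BaF3 cells (Mus musculus) for antiproliferative activity, read by CCK-8 assay, with a stated time of 72 h (a lower number here means a stronger inhibitor of growth, a higher number a weaker inhibitor of growth), compound 3 (`O=C(CCSc1ccc2c(/C=C/c3ccccn3)n[nH]c2c1)Nc1cccc(Cl)c1`) gives 9350 nM as the higher of two numbers, and compound 1 (`Cc1ccc(C(=O)Nc2ccc(CN3CCN(C)CC3)c(C(F)(F)F)c2)cc1C#Cc1ncc2cccnn12`) gives 940 nM with a gap beyond the scatter. Compound 2 (`CNC(=O)CCSc1ccc2c(/C=C/c3ccccn3)n[nH]c2c1`) reports only a limit (> 10000 nM). Within the data shown here, the one measured step (an at least 1.0-fold lower number from compound 2 to compound 3 (0.02 log units; that floor lies within the scatter)) brings 3-chlorophenyl in place of methyl on an amide-type nitrogen and stays within the scatter. Compound 4 (`COc1cccc(NC(=O)CCSc2ccc3c(/C=C/c4ccccn4)n[nH]c3c2)c1`) carries methoxy in place of chloro on an aromatic carbon, meta to a large group (methoxy in place of chloro on an aromatic carbon). Among the measured compounds shown here, no measured step changes the chloro itself, so no step beyond the scatter is expected (a 1.0-fold lower number from compound 3 to compound 4 (0.02 log units; within the scatter)). The estimate for compound 4 is 9000 nM (expected range 4000 nM to 20000 nM).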

Compound 4, concentration for 50% growth inhibition: 3840 nM
The estimate for compound 4 lay 2.3-fold (0.37 log units) above the measured number; measured number outside the range, below it.
By their numbers in this assay, from the lowest: compound 1; then compound 4; then compound 3. At a limit, above all of these: compound 2.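

In this assay, among these compounds, the substituent at this place on the aromatic ring matters: methoxy in place of chloro gives a 2.4-fold lower number from compound 3 to compound 4 (0.39 log units; beyond the scatter), the only step here between two exact numbers. With 3-methoxyphenyl in place of methyl on the amide-type nitrogen, the shared core also shows an at least 2.6-fold lower number from compound 2 to compound 4 (0.41 log units; beyond the scatter), a change beyond the scatter that the 3-chlorophenyl group did not show. Compound 2 gives only a limit of the assay: the limit of > 10000 nM in this assay, at which 1 of the 4 values shown sits.

With only chloro and methoxy at this place, no trend can be drawn. Going by these compounds, whether an amine, a hydroxyl or an ethoxy group there would give a lower number remains open.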